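Adding a third methoxy to the dimethoxyphenyl compound

This account rests on a few compounds, and the source may have more. Where it says the series, first, only, none or still open, it means among the compounds named here.

compound 1 `COc1cccc(/C=C/C(=O)/C=C/c2ccc(OCc3cn(CCCOc4cc(=O)oc5ccccc45)nn3)c(OC)c2)c1` gives 52% 
compound 2 `COc1ccc(/C=C/C(=O)/C=C/c2ccc(OCc3cn(CCCOc4cc(=O)oc5ccccc45)nn3)c(OC)c2)cc1OC` gives 65% 
compound 3 `COc1cc(/C=C/C(=O)/C=C/c2ccco2)ccc1OCc1cn(CCCCCOc2cc(=O)oc3ccccc23)nn1` gives 33% 

In a functional assay on COLO 205 cells (Homo sapiens) for inhibition, read by sulforhodamine B assay, with a stated time of 48 h, tested at 50 uM (on this read-out higher numbers stand for more inhibition of growth at the one concentration tested and lower numbers for less inhibition of growth), compound 2 stands highest of the three, with compound 1 and compound 3 both lower by more than the scatter. Compound 4 `COc1cc(/C=C/C(=O)/C=C/c2cc(OC)c(OC)c(OC)c2)ccc1OCc1cn(CCCOc2cc(=O)oc3ccccc23)nn1` has not yet been measured. Its difference from compound 2 is methoxy in place of hydrogen on an aromatic carbon and turns 3,4-dimethoxyphenyl into 3,4,5-trimethoxyphenyl. Going by the values given here, only one measured step involves the same kind of exchange, a methoxy in place of hydrogen on an aromatic carbon, and it shows a number 13 percentage points higher from compound 1 to compound 2 (beyond the scatter) as its result. A similar or smaller rise is therefore expected, though one step is thin support. The expected step is a number 8 percentage points higher from compound 2 to compound 4 (within the scatter) in this estimate. Compound 4 is expected at 73% (range 58% to 86%).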

Compound 4, percent growth inhibition at one concentration: 74%
For compound 4 the middle estimate is 1 percentage points below the measured one, and the stated range covers the measured number.
By their numbers in this assay, from the lowest: compound 3; then compound 1; then compounds 2 and 4 (each within the scatter of the next).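

In this assay, the same exchange of hydrogen for methoxy that gave a number 13 percentage points higher from compound 1 to compound 2 (beyond the scatter) gives a number 9 percentage points higher from compound 2 to compound 4 (within the scatter) when it is made ortho to a methoxy group, so this further methoxy does not separate compound 4 from compound 2. Only taken across both additions does the change stand clear, with a number 22 percentage points higher from compound 1 to compound 4 (beyond the scatter). Nothing available here explains these numbers. On these data alone, it remains open whether an ethoxy, a hydroxyl or an amine at this place on the ring would hold the number, and whether the 3,4,5-trimethoxyphenyl compound would keep it with a longer chain.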